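Shortening the hexyl ether of compound 1 to isopropyl

The source may hold more compounds than are shown below. What is called first, only, known or untested is meant among the compounds shown, and "the series" means these compounds.

Compound 1 `CCCCCCOc1ccc2c(=O)c(-c3ccc(O)cc3)coc2c1`: 1500 nM
Compound 2 `O=C(O)CCCCCCCCCCCCCCCOc1ccc2c(=O)c(-c3ccc(O)cc3)coc2c1`: > 9000 nM
Compound 3 `O=C(O)CCCCCCCOc1ccc2c(=O)c(-c3ccc(O)cc3)coc2c1`: 40 nM

Of the compounds shown here, three sharing the core of compound 1 have been tested in an assay (Cricetulus griseus) for inhibition of aldehyde dehydrogenase, mitochondrial (Homo sapiens); a higher number here means a weaker inhibitor, a lower number a stronger inhibitor. Compound 1 gives 1500 nM, the highest of the two plain numbers; compound 3 sits a large step away, a 38-fold lower number from compound 1 to compound 3 (1.57 log units; beyond the scatter). Compound 2 returns only a limit, > 9000 nM, and so is not a number (the limit of > 9000 nM in this assay, at which 1 of the 3 values shown sits). The other measured steps, an at least 6.0-fold higher number from compound 1 to compound 2 (0.77 log units; beyond the scatter) and an at least 220-fold lower number from compound 2 to compound 3 (2.35 log units; beyond the scatter), concern chains carrying a carboxylic acid.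

Compound 4 `CC(C)Oc1ccc2c(=O)c(-c3ccc(O)cc3)coc2c1` carries a different change: isopropyl in place of hexyl on an oxygen on an aromatic ring. Among the measured compounds shown here, no measured step bears on this change, since all three describe carboxy-bearing extensions rather than a shorter plain chain. With no guidance beyond the scatter, a modest weakening is expected, a 2.0-fold higher number from compound 1 to compound 4 (0.30 log units; within the scatter). Compound 4 is therefore estimated at 3000 nM, within the range 1000 nM to 9000 nM.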

Compound 4, half-maximal inhibitory concentration: 80 nM
The estimate for compound 4 lay 38-fold (1.57 log units) above the measured number; the whole stated range lies above it.
By their numbers in this assay, from the lowest: compounds 3 and 4 (each within the scatter of the next); then compound 1. At a limit, above all of these: compound 2.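

Among the compounds shown here, on this oxygen on an aromatic ring, the plain chain alone turns out to matter a great deal in this assay: isopropyl in place of hexyl gives a 19-fold lower number from compound 1 to compound 4 (1.27 log units; beyond the scatter), a shift the earlier compounds could not show, as each of their steps involved a chain carrying a carboxylic acid. Compound 3 gives 40 nM and compound 4 gives 80 nM, values within the scatter of each other, so a number this low does not require a carboxylic acid on the chain. Nothing measured here explains why the smaller group gives the lower number.

Between isopropyl and hexyl, the shown compounds leave the course of the change open, including whether a propyl or butyl chain stays as low as compound 4. Also open, from the compounds shown here alone, is what a methyl group, or a short chain ending in an amine, would give on this oxygen.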